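The compounds below may be only part of what the source reports. "The series", "measured", "known", "first", "only" and "open" are said of these compounds alone.

Among the compounds with values here, in an ADME assay on MT4 cells (Homo sapiens) for cytotoxicity, read by MTT assay (a higher number here means that more compound is tolerated, a lower number that less compound is tolerated), compound 1 `Cc1cc(C)cc(S(=O)(=O)c2c(C(=O)Nc3ccccc3O)[nH]c3ccc(Cl)cc23)c1` gives 19700 nM and compound 2 `Cc1cc(C)cc(S(=O)(=O)c2c(C(=O)NCc3ccccc3N)[nH]c3ccc(Cl)cc23)c1` gives 46200 nM, so compound 2 holds the higher of the only two numbers so far. Compound 3 `Cc1cc(C)cc(S(=O)(=O)c2c(C(=O)NC(C)c3ccccc3O)[nH]c3ccc(Cl)cc23)c1` has not yet been measured. Its difference from compound 2 is a group of 9 heavy atoms (8 carbon, 1 oxygen; one six-membered aromatic ring of carbon only) in place of a group of 8 heavy atoms (7 carbon, 1 nitrogen; one six-membered aromatic ring of carbon only), on an amide-type nitrogen. Within the data shown here, one measured step bears on this change: a 2.3-fold higher number from compound 1 to compound 2 (0.37 log units; beyond the scatter), a modest step that also exchanges the group on the amide-type nitrogen. The group in compound 3 contains oxygen, as the 2-hydroxyphenyl group of compound 1 does, so some return toward the value of compound 1 is plausible. A single step establishes no trend, however, and the data do not separate the effect of the added carbon from that of the exchange of nitrogen for oxygen. In this assay, among the measured compounds shown here, a shift toward a lower number is therefore expected, but no step clearly beyond the scatter. The expected move is a 1.8-fold lower number from compound 2 to compound 3 (0.25 log units; within the scatter). For compound 3 the estimated value is 26000 nM, with an expected range of 11000 nM to 60000 nM.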

Compound 3, half-maximal cytotoxic concentration: 21800 nM
For compound 3 the middle estimate is 1.2-fold (0.08 log units) above the measured one, and the stated range covers the measured number.
By their numbers in this assay, from the lowest: compounds 1 and 3 (each within the scatter of the next); then compound 2.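

In this assay, the two groups on the amide-type nitrogen that contain oxygen give numbers that cannot be told apart, with a 1.1-fold higher number from compound 1 to compound 3 (0.04 log units; within the scatter), although the group in compound 3 has more heavy atoms than the 2-hydroxyphenyl group of compound 1. The 2-aminobenzyl group now stands apart from both oxygen-containing groups, since a 2.1-fold lower number from compound 2 to compound 3 (0.33 log units; beyond the scatter) joins the earlier 2.3-fold higher number from compound 1 to compound 2 (0.37 log units; beyond the scatter), both modest and beyond the scatter. Across these three compounds, the number therefore follows the exchange of nitrogen for oxygen in the group more closely than its heavy-atom count, a reading that rests on a single nitrogen-containing group.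

Compound 2 and compound 3 differ in both the heteroatom and the carbon count, so a 2-hydroxybenzyl or a 2-aminophenyl group on the same nitrogen would be needed to separate the two contributions. From the compounds shown here alone, the response of this assay to a different kind of group at this place, such as a carboxylic acid or a dimethylamino chain, remains open. No supporting measurement accounts for these differences.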